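A few compounds are considered here, and "the series" means these few. Any claim that something is new, unique, unknown or untested is made for them only; others in the source may bear on it.

Measured so far:
Compound 1, `COc1ccc(CNC(=O)c2cn(C3CC3)c3cc(N4CCC(C(N)=O)CC4)c(F)cc3c2=O)cc1`: in an ADME assay on J774.1 cells (Mus musculus) for cytotoxicity, read by resazurin assay, with a stated time of 48 h (on this read-out lower numbers stand for stronger inhibition and higher numbers for weaker inhibition), compound 1 gives > 100000 nM, a limit of the assay rather than a number.
Compound 2, `CCCCn1cc(C(=O)NCc2ccc(OC)cc2)c(=O)c2cc(F)c(N3CCC(C(N)=O)CC3)cc21`: in this assay compound 2 gives 40800 nM.
Compound 3, `CCCn1cc(C(=O)NCc2ccco2)c(=O)c2cc(F)c(N3CCC(C(N)=O)CC3)cc21`: in this assay compound 3 gives 56900 nM.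

Compound 3 holds the higher of the two plain numbers, yet its value and that of compound 2 lie within the scatter of each other, so no order between them can be read. Going by the values given here, the only measured step, an at least 2.4-fold lower number from compound 1 to compound 2 (0.38 log units; beyond the scatter), concerns butyl in place of cyclopropyl on an aromatic nitrogen and does not touch the change now in hand. Compound 4, `CCCn1cc(C(=O)NCc2ccc(OC)cc2)c(=O)c2cc(F)c(N3CCC(C(N)=O)CC3)cc21`, differs from compound 3 by 4-methoxyphenyl in place of furan-2-yl on a saturated chain carbon bound to an amide-type nitrogen. Compound 2 already carries 4-methoxybenzyl and gives a plain number in this assay. Among the compounds with values here, with no step bearing on this change, compound 4 is expected to move by a 1.2-fold lower number from compound 3 to compound 4 (0.07 log units; within the scatter), nothing beyond the scatter. Compound 4 is estimated at 48000 nM, between 22000 nM and 100000 nM.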

Compound 4, half-maximal inhibitory concentration: 41400 nM
Compound 4: middle estimate off by 1.2-fold (0.06 log units), on the high side; measured number inside the range.
By their numbers in this assay, from the lowest: compounds 2, 4 and 3 (each within the scatter of the next). At a limit, above all of these: compound 1.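

In this assay, 4-methoxyphenyl in place of furan-2-yl gives a 1.4-fold lower number from compound 3 to compound 4 (0.14 log units; within the scatter) and so shows no readable effect of this swap on a saturated chain carbon bound to an amide-type nitrogen. Going from butyl to propyl with the 4-methoxybenzyl kept gives a 1.0-fold higher number from compound 2 to compound 4 (0.01 log units; within the scatter) and again shows none. Going by these compounds alone, only the step of an at least 2.4-fold lower number from compound 1 to compound 4 (0.38 log units; beyond the scatter) sets propyl apart from cyclopropyl, and its size rests on a limit: the limit of > 100000 nM in this assay, at which 1 of the 4 values shown sits. Still open, as far as these compounds go, is whether a carboxylic acid or an amine in place of 4-methoxyphenyl, or a longer chain such as hexyl in place of propyl, would move the number.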